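A few compounds are considered here, and "the series" means these few. Any claim that something is new, unique, unknown or untested is made for them only; others in the source may bear on it.

Measured in a functional assay on L02 cells (Homo sapiens) for inhibition, read by Griess assay, with stated times of 1 h and 24 h; a higher number here means a weaker inhibitor, a lower number a stronger inhibitor:

Compound 1, `CNc1nc(/C=C/c2ccccc2)nc2ccsc12`, gives > 1000000 nM, which is a limit of the assay and not a number.
Compound 2, `CN(C)c1nc(/C=C/c2ccccc2)nc2ccsc12`, gives > 1000000 nM, again a limit of the assay.
Compound 3, `CNc1nc(/C=C/c2cc(OC)c(OC)c(OC)c2)nc2ccsc12`, gives > 1000000 nM, also a limit of the assay.

Compound 1 and compound 2 differ in one place: methyl in place of hydrogen on a nitrogen on an aromatic ring. Going by these compounds, because both values are limits, the step that the two limits leave unreadable from compound 1 to compound 2 cannot be read; its size is unknown. The difference between the core of compound 1 and the core of compound 3 is not broken down here.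

Compound 4, `COc1cc(/C=C/c2nc(N(C)C)c3sccc3n2)cc(OC)c1OC`, has not yet been measured in this assay . It differs from compound 3 by the same change seen from compound 1 to compound 2: methyl in place of hydrogen on a nitrogen on an aromatic ring. All three measured values sit at the same limit, (the limit of > 1000000 nM in this assay, at which 3 of the 3 values shown sit), so no change among them has yet moved a value off it. Compound 4 is therefore expected to remain at that limit as well, with an estimated step of a number no higher from compound 3 to compound 4 (the limit leaves the size open) of essentially nothing; the estimate for compound 4 is 1000000 nM, between 300000 nM and 3000000 nM.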

Compound 4, half-maximal inhibitory concentration: > 1000000 nM
Compound 4: only a limit was reported (the forecaster's own chance of this, stated with the estimate: 85%); the middle value sits exactly at the limit.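

Compound 3 and compound 4 each give a limit and not a number in this assay, and no size can be read for the step between them. The compounds shown leave open how strongly any of them inhibits and whether any change to them would bring a value off this limit: the limit of > 1000000 nM in this assay, at which 4 of the 4 values shown sit.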